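From a Pentyl Chain to a Phenyl Ring

The source may report more compounds than this note shows. Statements on the series, on what has been measured and on what is new or still open speak of the compounds shown alone.

Compounds measured so far:
- compound 1 `COc1nc2ccc(Br)cc2cc1C(c1ccccc1)n1cc(-c2ccc(OC(F)(F)F)cc2)nn1`: in an ADME assay on HeLa cells (Homo sapiens) for cytotoxicity, read by sulforhodamine B assay, with a stated time of 48 h, tested at 10 uM (a lower number here means less inhibition, a higher number more inhibition at the concentration tested (going by the name of the read-out)), compound 1 gives -2.24%
- compound 2 `CCCCCc1cn(C(c2ccccc2)c2cc3cc(Br)ccc3nc2OC)nn1`: in this assay compound 2 gives -9.81%

Both numbers sit close to zero, so at the tested concentration neither compound measurably held back the growth of the cells. Compound 2 has the lowest of the two numbers, with compound 1 as its nearest neighbour, and the step of a number 7.6 percentage points lower from compound 1 to compound 2 (within the scatter) lies within the scatter, so the two compounds cannot be ranked against each other.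

The unmeasured compound is compound 3 `COc1nc2ccc(Br)cc2cc1C(c1ccccc1)n1cc(-c2ccccc2)nn1`. Its change from compound 2 is phenyl in place of pentyl on an aromatic carbon. Within the data shown here, the only step on hand, a number 7.6 percentage points lower from compound 1 to compound 2 (within the scatter), exchanged an aryl group for the pentyl chain at this same place without moving the number beyond the scatter; the present change puts an aryl group back at that place. No step beyond the scatter is therefore expected in this assay. Compound 3 is estimated at -5%, with a range from -18% to 8%. The step this estimate implies is a number 4.8 percentage points higher from compound 2 to compound 3 (within the scatter), expected to stay within the scatter.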

Compound 3, a percentage reported as inhibition, at one concentration (the size of the read-out at that concentration, not a potency): 13.9%
The estimate for compound 3 lay 18.9 percentage points below the measured number; the whole stated range lies below it.
By their numbers in this assay, from the lowest: compounds 2 and 1 (each within the scatter of the next); then compound 3.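

In this assay, among these compounds, this place on the five-membered ring turns out to matter: with phenyl in place of pentyl there is a number 23.7 percentage points higher from compound 2 to compound 3 (beyond the scatter), the first step to clear the scatter. The substituent on that phenyl ring also counts, since hydrogen in place of trifluoromethoxy gives a number 16.1 percentage points higher from compound 1 to compound 3 (beyond the scatter), so the plain phenyl of compound 3 stands apart from both the 4-(trifluoromethoxy)phenyl of compound 1 and the pentyl of compound 2, while those two remain indistinguishable from each other. Both steps are modest, and nothing measured here explains why the plain phenyl ring gives the highest number of the three.

The compounds shown leave open whether this rise is specific to the unsubstituted phenyl ring or would also appear with a chlorine atom, a methyl group or an amine in place of that hydrogen. They also leave open whether a shorter chain such as ethyl, or a different ring such as pyridine, at the same place would read closer to compound 2 or to compound 3.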